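Step from furan-2-yl to phenyl in the 2-chlorophenyl series

The source may hold more compounds than are shown below. What is called first, only, known or untested is meant among the compounds shown, and "the series" means these compounds.

Measured so far:
compound 1, `Oc1ccc(-c2cc(-c3ccccc3)nc(-c3ccccc3Cl)c2)cc1`: 5460 nM
compound 2, `Oc1cccc(-c2cc(-c3ccco3)nc(-c3ccccc3Cl)c2)c1`: 2010 nM

Both compounds were run in a functional assay on T47D cells (Homo sapiens) for cytotoxicity, read by CCK-8 assay and cell counting, with a stated time of 2 days; on this read-out lower numbers stand for stronger inhibition and higher numbers for weaker inhibition. Compound 2 holds the lowest of the two numbers; the nearest is compound 1, whose number is higher by a margin beyond the usual scatter. Within the data shown here, no single-point step between the two measured compounds is available, as they differ in more than one place.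

Compound 3, `Oc1cccc(-c2cc(-c3ccccc3)nc(-c3ccccc3Cl)c2)c1`, is not yet measured. It differs from compound 2 in one place: phenyl in place of furan-2-yl on an aromatic carbon. Among the measured compounds shown here, the only measured compound that carries a phenyl group in that place is compound 1, and in this assay compound 1 gives 5460 nM.

The step from compound 2 to compound 3 is expected to move the number upward, toward the value of compound 1, by a modest amount that may not exceed the scatter: a 1.7-fold higher number from compound 2 to compound 3 (0.24 log units; within the scatter). Compound 3 is therefore estimated at 3500 nM, with a plausible range from 1500 nM to 8000 nM.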

Compound 3, half-maximal inhibitory concentration: 2920 nM
Beside the measured number, compound 3's estimate is 1.2-fold (0.08 log units) above it; the range from low to high includes it.
By their numbers in this assay, from the lowest: compounds 2, 3 and 1 (each within the scatter of the next, the first and the last beyond it).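

In this assay, phenyl in place of furan-2-yl on the aromatic carbon next to the ring nitrogen gives a 1.5-fold higher number from compound 2 to compound 3 (0.16 log units; within the scatter) with the 3-hydroxyphenyl group held constant, so this single exchange of aromatic rings is not resolved from the scatter in this series. With phenyl held constant, 3-hydroxyphenyl in place of 4-hydroxyphenyl gives a 1.9-fold lower number from compound 1 to compound 3 (0.27 log units; within the scatter) and is likewise not resolved, so neither single change on its own separates the compounds of its pair in this read-out. No further data bear on these two steps, and they remain plain observations on the numbers.

Still open, as far as these compounds go, is whether an amine, a carboxylic acid or a longer chain on this aromatic carbon would move the number beyond the scatter, as the comparison so far covers only furan-2-yl and phenyl. Also open, from the compounds shown here alone, is how 4-hydroxyphenyl behaves alongside furan-2-yl, and whether any group other than 2-chlorophenyl, such as 2-fluorophenyl or an unsubstituted phenyl, would hold the numbers in the same range.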